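A few compounds are considered here, and "the series" means these few. Any claim that something is new, unique, unknown or untested is made for them only; others in the source may bear on it.

Measured so far:
compound 1, `Brc1ccccc1OCC1=NCCO1`, 20%
compound 2, `Cc1ccccc1OCC1=NCCO1`, 20%
compound 3, `O=[N+]([O-])c1ccccc1OCC1=NCCO1`, 25%

Among the measured compounds shown here, in a toxicity assay on the whole organism with Rattus norvegicus as the target, at a dose of 200 mg/kg by the oral route (a higher number here means a stronger effect of the compound at the dose given, a lower number a weaker effect), compound 2 stands level with compound 1, and the only other number, that of compound 3, lies a number 5 percentage points higher from compound 2 to compound 3 (within the scatter). Compound 4, `Cc1ccc(OCC2=NCCO2)c(C)c1`, differs from compound 2 by methyl in place of hydrogen on an aromatic carbon. For the measured compounds named here, no measured step puts a methyl where a hydrogen stood: no change at the digits printed from compound 1 to compound 2 (within the scatter), a number 5 percentage points higher from compound 1 to compound 3 (within the scatter) and a number 5 percentage points higher from compound 2 to compound 3 (within the scatter) each exchange one ring substituent for another, and each stays within the scatter. Going by the values given here, the three measured compounds thus show only that swapping the group on this ring leaves this assay largely unmoved, and the added methyl is expected to do likewise. The expected step is no change at the digits printed from compound 2 to compound 4 (within the scatter). Compound 4 is therefore estimated at 20%, between 8% and 35%.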

Compound 4, a percentage reported as activity, at one dose (the size of the read-out at that dose, not a potency): 25%
For compound 4 the middle estimate is 5 percentage points below the measured one, and the stated range covers the measured number.
By their numbers in this assay, from the lowest: compounds 1, 2, 3 and 4 (each within the scatter of the next).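

The steps among compound 1, compound 2 and compound 3 only exchanged one ring group for another. Here a methyl replaces a hydrogen on an aromatic carbon, meta to a methyl group and para to a group of 7 heavy atoms, and this assay shows a number 5 percentage points higher from compound 2 to compound 4 (within the scatter), so a second ring group at this position stays within the scatter. No measurement available here explains this result.

As far as these compounds go, whether an amine, a carboxylic acid or a longer chain at this position would also stay within the scatter remains open.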